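Naphthyl thiazolidinedione amides: removing the aryl methoxy

This account rests on a few compounds, and the source may have more. Where it says the series, first, only, none or still open, it means among the compounds named here.

Measured compounds:
compound 1 `Cc1ccc(NC(=O)COc2ccc3cc(/C=C4/SC(=O)NC4=O)ccc3c2)cc1Cl` 1100 nM
compound 2 `O=C(CN1C(=O)S/C(=C/c2ccccn2)C1=O)Nc1nc2ccccc2s1` 9300 nM
compound 3 `COc1cccc(NC(=O)COc2ccc3cc(/C=C4/SC(=O)NC4=O)ccc3c2)c1` 1600 nM

In an assay on isolated protein for inhibition of histone deacetylase 4 (Homo sapiens), with a stated time of 1 h (on this read-out higher numbers stand for weaker inhibition and lower numbers for stronger inhibition), compound 3 gives 1600 nM, the second highest of the three numbers. Its nearest neighbour is compound 1, where the step of a 1.5-fold higher number from compound 1 to compound 3 (0.16 log units; within the scatter) stays within the scatter; compound 2, with a different core, gives 9300 nM, far higher.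

Compound 4 `O=C(COc1ccc2cc(/C=C3/SC(=O)NC3=O)ccc2c1)Nc1ccccc1` differs from compound 3 by hydrogen in place of methoxy on an aromatic carbon; read one bond further out, 3-methoxyphenyl to phenyl. For the measured compounds named here, no measured step removes this group outright. Going by the values given here, the only step on the same aryl amide, from compound 1 to compound 3, exchanged one substituent pattern for another and stayed within the scatter, so for compound 4 the expected step of a 1.1-fold higher number from compound 3 to compound 4 (0.05 log units; within the scatter) in this assay is none beyond the scatter. Compound 4 is estimated at 1800 nM, with a range of 900 nM to 3600 nM.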

Compound 4, half-maximal inhibitory concentration: 2100 nM
Beside the measured number, compound 4's estimate is 1.2-fold (0.07 log units) below it; measured number inside the range.
By their numbers in this assay, from the lowest: compounds 1, 3 and 4 (each within the scatter of the next); then compound 2.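

In this assay, removing the methoxy outright gives a 1.3-fold higher number from compound 3 to compound 4 (0.12 log units; within the scatter), so on this aromatic carbon hydrogen serves as well as methoxy within the scatter. Taking both substituents off the aryl ring of compound 1 gives a 1.9-fold higher number from compound 1 to compound 4 (0.28 log units; within the scatter), so the plain phenyl also stays level with the 3-chloro-4-methylphenyl amide. Nothing available explains why these steps are so small. From the compounds shown here alone, whether an amine, a carboxylic acid or a longer chain on this aromatic carbon would move the number beyond the scatter remains open.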